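The source may hold more compounds than are shown below. What is called first, only, known or untested is meant among the compounds shown, and "the series" means these compounds.

Compounds measured:
- compound 1 `O=C(/C=C/c1ccc2c(c1)B(O)OC2)c1cccc(F)c1` — > 10 ug/mL
- compound 2 `COc1cc(C(=O)/C=C/c2ccc3c(c2)B(O)OC3)cc(OC)c1OC` — > 10 ug/mL

In an ADME assay on L929 cells (Mus musculus) for cytotoxicity, read by resazurin assay, with a stated time of 72 h (a higher number here means a weaker inhibitor, a lower number a stronger inhibitor), compound 1 gives only a limit, > 10 ug/mL, not a number. Compound 2 likewise gives only a limit, > 10 ug/mL. Both values sit at the limit of > 10 ug/mL in this assay, at which 2 of the 2 values shown sit, so compound 1 cannot be placed relative to compound 2. Compound 3 `Nc1cccc(C(=O)/C=C/c2ccc3c(c2)B(O)OC3)c1` differs from compound 1 by amino in place of fluoro on an aromatic carbon. For the measured compounds named here, no measured step between compounds shows how this change acts here. Compound 3 is expected to remain at the limit, with an expected step of a number no higher from compound 1 to compound 3 (the limit leaves the size open) of essentially none. Compound 3 is estimated at 10 ug/mL, between 5 ug/mL and 20 ug/mL.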

Compound 3, half-maximal inhibitory concentration: 10 ug/mL
Compound 3: middle estimate and measured number agree at the digits printed; low and high end bracket the measured number.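

In this assay compound 3 gives the only actual number of the compounds shown, 10 ug/mL. Compound 1 gives only a limit, > 10 ug/mL. The change from 3-fluorophenyl to 3-aminophenyl therefore reads as a number no higher from compound 1 to compound 3 (the limit leaves the size open), so amino at this place can be said only not to raise the number, and the size of the step cannot be read: the limit of > 10 ug/mL in this assay, at which 2 of the 3 values shown sit.

On these data alone, it remains open whether a hydroxyl, a methoxy or a carboxylic acid at this place would give a number clearly apart from that of compound 3. As far as these compounds go, it also remains open how far compound 1 really stands from compound 3.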